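Swapping the carbonyl side group from compound 3 to compound 4

The source may report more compounds than this note shows. Statements on the series, on what has been measured and on what is new or still open speak of the compounds shown alone.

In a functional assay on HCT-116 cells (Homo sapiens) for inhibition, read by MTT assay, with a stated time of 48 h (on this read-out lower numbers stand for stronger inhibition and higher numbers for weaker inhibition), compound 1 (`COc1ccc(CN(C(=O)CN=[N+]=[N-])c2cc(OC)c(OC)c(OC)c2)cc1O`) gives 410 nM, compound 2 (`COc1ccc(CN(C(=O)CCCl)c2cc(OC)c(OC)c(OC)c2)cc1O`) gives 150 nM and compound 3 (`COc1ccc(CN(C(=O)/C=C/CBr)c2cc(OC)c(OC)c(OC)c2)cc1O`) gives 59 nM, the lowest of the three. Compound 4 (`COc1ccc(CN(C(=O)C[Se]C#N)c2cc(OC)c(OC)c(OC)c2)cc1O`) is not yet measured. The change is a group of 4 heavy atoms (2 carbon, 1 nitrogen, 1 selenium; no ring) in place of a group of 4 heavy atoms (3 carbon, 1 bromine; no ring), on a carbonyl carbon, on a carbonyl carbon. Three measured steps alter the group at that carbon: a 2.7-fold lower number from compound 1 to compound 2 (0.44 log units; beyond the scatter), a 2.5-fold lower number from compound 2 to compound 3 (0.41 log units; beyond the scatter) and a 6.9-fold lower number from compound 1 to compound 3 (0.84 log units; beyond the scatter). All are modest, and none involves the entering group, so they indicate only a likely size. With compound 3 at 59 nM, the low end of the series, a modest rise in this assay is expected rather than a further fall. The expected step is a 1.9-fold higher number from compound 3 to compound 4 (0.27 log units; within the scatter). The estimate for compound 4 is 110 nM, with an expected range of 30 nM to 400 nM.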

Compound 4, half-maximal inhibitory concentration: 310 nM
Compound 4: the middle estimate sits 2.8-fold (0.45 log units) below what was measured; the range from low to high includes it.
By their numbers in this assay, from the lowest: compound 3; then compound 2; then compounds 4 and 1 (each within the scatter of the next).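

In this assay the selenium-bearing group on this carbonyl carbon does not keep the level of 3-bromoprop-1-en-1-yl, with a 5.3-fold higher number from compound 3 to compound 4 (0.72 log units; beyond the scatter) as the largest new step. It also trails the 2-chloroethyl group, with a 2.1-fold higher number from compound 2 to compound 4 (0.32 log units; beyond the scatter) beyond the scatter, while a 1.3-fold lower number from compound 1 to compound 4 (0.12 log units; within the scatter) leaves it inseparable from azidomethyl. No available data account for these steps.

Still open, on these data alone, is whether an amine, a carboxylic acid or a longer chain on this carbonyl carbon would match compound 3. A 3-chloroprop-1-en-1-yl group would test whether the bromine matters there.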